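Chloro for methyl on the aryl ring: compound 4

This account rests on a few compounds, and the source may have more. Where it says the series, first, only, none or still open, it means among the compounds named here.

Compound 3 `COc1c(-c2ccc(C)cc2)oc2ccc(C(=O)O)cc2c1=O` gives 4% in a functional assay on the whole organism (stomach) for inhibition, with Rattus norvegicus as the target, at a dose of 80 mg/kg; a higher number here means more inhibition at the dose given (going by the name of the read-out), a lower number less inhibition. Compound 1 `CCCCCCc1ccc(-c2cc(=O)c3cc(C(=O)O)ccc3o2)cc1` gives 2% and compound 2 `Cc1ccc(-c2oc3ccc(C(=O)O)cc3c(=O)c2O)cc1` gives 6%; the three numbers all lie within the scatter of one another, so compound 3 stands nowhere apart from them. Within the data shown here, the single measured step, a number 2 percentage points lower from compound 2 to compound 3 (within the scatter), concerns methyl in place of hydrogen on an oxygen on an aromatic ring and is within the scatter. Compound 4 `COc1c(-c2ccc(Cl)cc2)oc2ccc(C(=O)O)cc2c1=O` differs from compound 3 by chloro in place of methyl on an aromatic carbon. Among the measured compounds shown here, no measured step concerns chloro in place of methyl, so nothing here bears directly on it, and the measured values give no sign of any shift. The step from compound 3 to compound 4 is therefore expected to be a number 1 percentage points higher from compound 3 to compound 4 (within the scatter), nothing beyond the scatter. Compound 4 is estimated at 5%, within 0% to 15%.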

Compound 4, a percentage reported as inhibition, in the whole organism at one dose (the size of the read-out at that dose, not a potency): 34%
The estimate for compound 4 lay 29 percentage points below the measured number; measured number above the stated range.
By their numbers in this assay, from the lowest: compounds 1, 3 and 2 (each within the scatter of the next); then compound 4.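

In this assay, 4-methylphenyl to 4-chlorophenyl gives a number 30 percentage points higher from compound 3 to compound 4 (beyond the scatter), the first listed step beyond the scatter, whereas the step on the oxygen stayed within it. This aromatic carbon, para to a large group, is therefore a place where a one-atom exchange of methyl for chloro changes the read-out at this dose. No measurement shown accounts for the size of this step.

Open, on these data alone, is whether bromo or fluoro on the same carbon would give a similar number. Also open, as far as these compounds go, is whether chloro would give a comparable step on the core of compound 2.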